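Swapping a methoxyphenyl for a dichlorophenyl: an expected cytotoxicity

This account rests on a few compounds, and the source may have more. Where it says the series, first, only, none or still open, it means among the compounds named here.

Compound 1: `CNC(=O)c1cc(Oc2ccc(C(=O)/C=C/c3cccc([N+](=O)[O-])c3)cc2)ccn1`. Compound 2: `CNC(=O)c1cc(Oc2ccc(C(=O)/C=C/c3cccc(Br)c3)cc2)ccn1`. Compound 3: `CNC(=O)c1cc(Oc2ccc(C(=O)/C=C/c3ccc(OC)cc3)cc2)ccn1`.

In a functional assay on HepG2 cells (Homo sapiens) for cytotoxicity, read by MTT assay, with a stated time of 72 h (a lower number here means a stronger inhibitor, a higher number a weaker inhibitor), compound 1 gives only > 50000 nM, a limit of the measurement rather than a number. Compound 2 gives 2870 nM in this assay. For compound 3 the entry in this assay is "not determined" (no result reported), so it stands nowhere on the numbers shown. Among the measured compounds shown here, the one measured step, an at least 17-fold lower number from compound 1 to compound 2 (1.24 log units; beyond the scatter), is bounded by the limit of > 50000 nM in this assay, at which 1 of the 3 values shown sits.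

Compound 4 is `CNC(=O)c1cc(Oc2ccc(C(=O)/C=C/c3ccc(Cl)c(Cl)c3)cc2)ccn1`. It differs from compound 3 by 3,4-dichlorophenyl in place of 4-methoxyphenyl on a double-bonded chain carbon bound to a double-bonded chain carbon. With no number for compound 3, no step size can be expected in this assay; compound 2, which carries a halogen on its aryl ring and gives 2870 nM, is the nearest reference. Compound 4 is therefore estimated at 2500 nM, between 600 nM and 12000 nM.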

Compound 4, half-maximal inhibitory concentration: 11400 nM
The estimate for compound 4 lay 4.6-fold (0.66 log units) below the measured number; the measured number falls inside the stated range.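

In this assay, a halogen on the aryl ring does not fix the result at this place, on a double-bonded chain carbon bound to a double-bonded chain carbon, since 3,4-dichlorophenyl and 3-bromophenyl differ beyond the scatter: a 4.0-fold higher number from compound 2 to compound 4 (0.60 log units; beyond the scatter). 3,4-Dichlorophenyl still keeps a measurable number where 3-nitrophenyl does not, with an at least 4.3-fold lower number from compound 1 to compound 4 (0.64 log units; beyond the scatter). Compound 1 stands at a limit, not a number: the limit of > 50000 nM in this assay, at which 1 of the 4 values shown sits.

The step from compound 3 to compound 4 cannot be read, as compound 3 has no number. As far as these compounds go, how a single chlorine, an amine or a carboxylic acid on this aryl ring would compare remains open.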